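A few compounds are considered here, and "the series" means these few. Any claim that something is new, unique, unknown or untested is made for them only; others in the source may bear on it.

In a functional assay on MGC-803 cells (Homo sapiens) for inhibition, read by MTT assay, with a stated time of 72 h (on this read-out lower numbers stand for stronger inhibition and higher numbers for weaker inhibition), the measured compounds read as follows:

Compound 1 `C[C@@H]1CCN(c2cc(-c3ccccc3)nc3ncnn23)C[C@@H]1N(C)c1ncnc2[nH]ccc12` gives 84900 nM in this test
Compound 2 `Cc1cc(N2CC[C@@H](C)[C@@H](N(C)c3ncnc4[nH]ccc34)C2)n2nc(SCc3ccc(F)cc3)nc2n1` gives 11900 nM in this test
Compound 3 `CCCCCc1c(C)nc2nc(SCc3ccc(Cl)cc3)nn2c1N1CC[C@@H](C)[C@@H](N(C)c2ncnc3[nH]ccc23)C1` gives > 100000 nM as a limit of the assay, not a number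

Of the two true numbers, compound 2 at 11900 nM is the lower, and the higher number of compound 1 lies beyond the usual scatter from it. Compound 4 `Cc1cc(N2CC[C@@H](C)[C@@H](N(C)c3ncnc4[nH]ccc34)C2)n2nc(SCc3ccc(Br)cc3)nc2n1` has not yet been measured. It differs from compound 2 in one place, counted as bromo in place of fluoro on an aromatic carbon and read in words as bromo in place of fluoro on an aromatic carbon, para to a large group. The (4-fluorobenzyl)sulfanyl group thus becomes (4-bromobenzyl)sulfanyl.

Going by the values given here, no pair of measured compounds isolates this swap, so the data give no direct size for it. With one halogen exchanged for another and the rest of the molecule kept, no change beyond the scatter is expected, and no firm direction. The expected step of a 1.1-fold lower number from compound 2 to compound 4 (0.03 log units; within the scatter) in this assay is therefore small. The estimate starts from compound 2 at 11900 nM and keeps a wide margin on both sides. The estimated value for compound 4 is 11000 nM with an expected range from 4000 nM to 30000 nM in the same test.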

Compound 4, half-maximal inhibitory concentration: 4020 nM
Compound 4: the middle estimate sits 2.7-fold (0.44 log units) above what was measured; the measured number falls inside the stated range.
By their numbers in this assay, from the lowest: compound 4; then compound 2; then compound 1. At a limit, above all of these: compound 3.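

In this assay, the exchange of fluoro for bromo on an aromatic carbon, para to a large group, gives a 3.0-fold lower number from compound 2 to compound 4 (0.47 log units; beyond the scatter). This shows that the position is not silent: swapping one halogen for another here moves the number by more than repeat measurements would, though the step is modest in size. Until now, no two measured compounds differed in one place only, so this is the first single change whose size can be read, but nothing shown explains why bromo gives the lower number.

As far as these compounds go, whether the number would keep falling or turn back with an iodo, a methoxy or an amine at the same place remains open, since one pair gives a direction for this one swap only. Compound 3 carries a (4-chlorobenzyl)sulfanyl group but differs in other places as well, and its > 100000 nM is a limit of the assay, not a number, so it cannot show where chloro would fall relative to fluoro and bromo.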